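Vinyl in place of 4-methylphenyl on the ester

A few compounds are considered here, and "the series" means these few. Any claim that something is new, unique, unknown or untested is made for them only; others in the source may bear on it.

Measured in an ADME assay on Vero cells (Chlorocebus sabaeus) for cytotoxicity, read by MTT assay, with a stated time of 48 h; a higher number here means a weaker inhibitor, a lower number a stronger inhibitor:
- compound 1 `O=c1cc(N2CCN(CC3CCC(OS(=O)(=O)c4cccnc4)CC3)CC2)sc2c([N+](=O)[O-])cc(C(F)(F)F)cc12` gives > 64 ug/mL
- compound 2 `Cc1ccc(C(=O)OC2CCC(CN3CCN(c4cc(=O)c5cc(C(F)(F)F)cc([N+](=O)[O-])c5s4)CC3)CC2)cc1` gives > 64 ug/mL

Compound 2 reads > 64 ug/mL as a limit and not as a number. Compound 1 reads > 64 ug/mL as a limit too. Among the compounds with values here, the series so far rests on the limit of > 64 ug/mL in this assay, at which 2 of the 2 values shown sit, and holds no number yet.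

Compound 3 `C=CC(=O)OC1CCC(CN2CCN(c3cc(=O)c4cc(C(F)(F)F)cc([N+](=O)[O-])c4s3)CC2)CC1` differs from compound 2 by vinyl in place of 4-methylphenyl on a carbonyl carbon with vinyl in place of 4-methylphenyl on a carbonyl carbon. Within the data shown here, the one measured step is a step that the two limits leave unreadable from compound 1 to compound 2 with (4-methylphenyl)carbonyl in place of (pyridin-3-yl)sulfonyl on an oxygen on a saturated carbon. Its two ends are limits and it offers no size to carry over. Among the measured compounds shown here, no measured step replaces the 4-methylphenyl group itself.

On these data alone, the expected a number no higher from compound 2 to compound 3 (the limit leaves the size open) in this assay is none beyond the scatter, though a lower value stays open and another limit is the likeliest report. Compound 3 is estimated at 64 ug/mL with an expected range from 20 ug/mL to 128 ug/mL on this reading.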

Compound 3, half-maximal inhibitory concentration: > 64 ug/mL
Compound 3 gave a limit, no number; the forecaster's own chance of this, stated with the estimate: 65%; the middle value lies on the limit itself.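

No step can be read among compound 1, compound 2 and compound 3 in this assay, as all three values rest on one limit and none is a number: the limit of > 64 ug/mL in this assay, at which 3 of the 3 values shown sit.

The compounds shown leave open whether (4-methylphenyl)carbonyl, vinylcarbonyl and (pyridin-3-yl)sulfonyl differ at all in this assay, and by how much.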